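A few compounds are considered here, and "the series" means these few. Any claim that something is new, unique, unknown or untested is made for them only; others in the source may bear on it.

Compound 1 `CCN(CC)C(=O)C1=C(C)NC(=O)NC1c1ccco1`: 31%
Compound 2 `CCN(CC)C(=O)C1=C(C)NC(=O)NC1c1cccs1`: 22%

Of the compounds shown here, two have been measured in an assay on membranes from HEK293 cells for displacement of a labelled ligand from adenosine receptor A2b (Homo sapiens), read by scintillation counting, with a stated time of 30 min, tested at 1 uM; a higher number here means more inhibition at the concentration tested (going by the name of the read-out), a lower number less inhibition. Compound 1 gives 31% and compound 2 gives 22%; the step of a number 9 percentage points lower from compound 1 to compound 2 (within the scatter) lies within the scatter, so on these numbers the two read-outs count as level, and compound 1 simply shares the top of a very short list.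

Compound 3 `CCC(CC)OC(=O)C1=C(C)NC(=O)NC1c1ccco1` has not yet been measured. It differs from compound 1 in one place: (pentan-3-yl)oxy in place of diethylamino on a carbonyl carbon. Going by the values given here, the only measured step, a number 9 percentage points lower from compound 1 to compound 2 (within the scatter), concerns the exchange of one aromatic ring for another on a saturated ring carbon and says nothing about swapping the group on the carbonyl carbon. With no comparison to lean on, no shift beyond the scatter is expected in either direction, and the range must stay wide. Compound 3 is therefore estimated at 25%, between 5% and 50%. That estimate means an expected step of a number 6 percentage points lower from compound 1 to compound 3 (within the scatter).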

Compound 3, a percentage reported as inhibition, at one concentration (the size of the read-out at that concentration, not a potency): 35%
Beside the measured number, compound 3's estimate is 10 percentage points below it; low and high end bracket the measured number.
By their numbers in this assay, from the lowest: compounds 2, 1 and 3 (each within the scatter of the next, the first and the last beyond it).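

At the carbonyl carbon, the only position changed here so far, (pentan-3-yl)oxy in place of diethylamino gives a number 4 percentage points higher from compound 1 to compound 3 (within the scatter) in this assay. The read-out therefore stays level when the group attached through nitrogen gives way to one attached through oxygen, and when the count of hydrogen-bond acceptors in the exchanged group goes from none to one. No outside evidence is available to explain this result.

The compounds shown leave open whether a carboxylic acid, a methoxy group or a cyclohexyloxy ring on the same carbonyl carbon would give a step beyond the scatter. They also leave open whether exchanging furan-2-yl for thiophen-2-yl would give a similar step when (pentan-3-yl)oxy occupies the carbonyl carbon.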